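Nitro to Bromo: A Swap Expected to Change Little

The source may report more compounds than this note shows. Statements on the series, on what has been measured and on what is new or still open speak of the compounds shown alone.

Of the compounds shown here, three have been measured in a functional assay on IMR-32 cells (Homo sapiens) for cytotoxicity, read by sulforhodamine B assay, with a stated time of 48 h; on this read-out lower numbers stand for stronger inhibition and higher numbers for weaker inhibition. Compound 1 `CC(=O)N1N=C(c2ccco2)CC1c1cccc([N+](=O)[O-])c1` gives 28900 nM in this assay. Compound 2 `COc1ccc(C2CC(c3cccc4ccccc34)=NN2C(C)=O)cc1` gives 4990 nM. Compound 3 `O=CCN1N=C(c2ccc3ccccc3c2)CC1c1cccc([N+](=O)[O-])c1` gives 3280 nM, the lowest of the three numbers. Its gap to compound 2 lies within the usual scatter of repeated measurements, so the two cannot be told apart on these data. Its gap to compound 1 lies beyond the scatter, so compound 3 does inhibit the cells more strongly than compound 1.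

Compound 4 `O=CCN1N=C(c2ccc3ccccc3c2)CC1c1cccc(Br)c1` has not yet been measured. It differs from compound 3 in a single place: bromo in place of nitro on an aromatic carbon. Everything else in the molecule stays the same. Within the data shown here, no pair of measured compounds differs by exactly this swap, so there is no direct step to lean on, and the three measured compounds differ from one another in several places at once. With no guide of that kind, the safest expectation is a step that stays within the scatter, with no clear direction.

Compound 4 is therefore expected to give about 4000 nM in this assay, with a range from 1500 nM to 12000 nM. The expected step from compound 3 to compound 4 is a 1.2-fold higher number from compound 3 to compound 4 (0.09 log units; within the scatter), which is estimated to lie within the scatter.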

Compound 4, half-maximal inhibitory concentration: 9870 nM
Compound 4: middle estimate off by 2.5-fold (0.39 log units), on the low side, and the stated range covers the measured number.
By their numbers in this assay, from the lowest: compounds 3, 2 and 4 (each within the scatter of the next, the first and the last beyond it); then compound 1.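

Compounds 1, 2 and 3 differ from one another in several places at once, so they could not show whether the group on this aromatic carbon matters by itself. Compounds 3 and 4 isolate that place, and going from 3-nitrophenyl to 3-bromophenyl in this assay gives a 3.0-fold higher number from compound 3 to compound 4 (0.48 log units; beyond the scatter) while the rest of the molecule stays the same, which means that on this core the nitro group goes with stronger inhibition of the cells than the bromo group, by a modest but real margin. Nothing available here explains the step, whether through the loss of the two hydrogen-bond acceptors counted for nitro or through anything else. Among these compounds, with only one pair, it remains open whether an amine, a nitrile or a carboxylic acid at this place would give a lower or a higher number than nitro or bromo. As far as these compounds go, it also remains open whether the same swap would give a step of similar size and direction on the core of compound 1, which carries the same 3-nitrophenyl group.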